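The source may hold more compounds than are shown below. What is called first, only, known or untested is meant among the compounds shown, and "the series" means these compounds.

Measured compounds:
compound 1 `CCCC#Cc1cn([C@@H]2O[C@H](CO)[C@@H](O)[C@H](O)[C@H]2O)c(=O)[nH]c1=O`: 123000 nM
compound 2 `CCCC#Cc1cn([C@@H]2O[C@H](CO)[C@@H](O)[C@H](O)[C@H]2O)c(=O)nc1N`: > 250000 nM

In a functional assay on CCRF-CEM cells (Homo sapiens) for cytotoxicity, with a stated time of 72 h (a higher number here means a weaker inhibitor, a lower number a stronger inhibitor), compound 1 gives 123000 nM. For compound 2 the reported value of > 250000 nM is a limit of the assay and not a number, as shown by the limit of > 250000 nM in this assay, at which 1 of the 2 values shown sits. Among the measured compounds shown here, compound 2 thus stands at the limit, with compound 1 the only member of the pair carrying an actual figure. For the measured compounds named here, no step between measured compounds is available. Compound 3 `CCCCCC#Cc1cn([C@@H]2O[C@H](CO)[C@@H](O)[C@H](O)[C@H]2O)c(=O)nc1N` differs from compound 2 by ethyl in place of hydrogen on a saturated chain carbon, three bonds along the chain from a triple-bonded carbon. Going by the values given here, with no measured step to give a direction, only a small change is expected, an at least 1.2-fold lower number from compound 2 to compound 3 (0.09 log units; that floor lies within the scatter), and likely none beyond the scatter. Compound 3 is expected to give about 200000 nM in this assay, with a range of 50000 nM to 500000 nM. Compound 3 may well be reported again only as a limit.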

Compound 3, half-maximal inhibitory concentration: > 250000 nM
Compound 3: only a limit was reported (the forecaster's own chance of this, stated with the estimate: 60%); middle value at least 1.2-fold (0.09 log units) from the limit.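

Compound 3 gives > 250000 nM in this assay, a limit and not a number. Compound 2 also carries only a limit, and no step can be read between compound 2 and compound 3. Going by these compounds, whether ethyl in place of hydrogen on this chain shifts the read-out at all remains open.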